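From a nitrile to a sulfur-bearing group on the benzyl ring

The compounds below may be only part of what the source reports. "The series", "measured", "known", "first", "only" and "open" are said of these compounds alone.

Of the compounds shown here, three sharing one core have been tested in an ADME assay on microsomes from liver (Mus musculus, strain CD1) for metabolic stability, read by HPLC, using NADPH, with a stated time of 30 min; a higher number here means faster removal of the compound, a lower number slower removal. Compound 3 `COc1cccc(NC(=O)c2nnn(Cc3ccc(C#N)cc3)c2N)c1` gives 2.5 mL.min-1.g-1 in this assay, the lowest of the two numbers in hand; its nearest neighbour is compound 2 `COc1cccc(NC(=O)c2nnn(Cc3ccc(OC(F)(F)F)cc3)c2N)c1`, which gives 2.9 mL.min-1.g-1, and the two lie within the scatter, as a 1.2-fold lower number from compound 2 to compound 3 (0.06 log units; within the scatter) shows. Compound 1 `COc1cccc(NC(=O)c2nnn(CC3CCNCC3)c2N)c1` is reported in this assay only as a limit, < 0.5 mL.min-1.g-1. That limit is the one described by the limit of < 0.5 mL.min-1.g-1 in this assay, at which 1 of the 3 values shown sits. Starting from that limit, the step of an at least 5.0-fold higher number from compound 1 to compound 3 (0.69 log units; beyond the scatter) is beyond the scatter.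

Compound 4 `COc1cccc(NC(=O)c2nnn(Cc3ccc([S+](C)[O-])cc3)c2N)c1` has not yet been measured. It differs from compound 3 in one place: a group of 3 heavy atoms (1 carbon, 1 oxygen, 1 sulfur; no ring) in place of a group of 2 heavy atoms (1 carbon, 1 nitrogen; no ring), on an aromatic carbon. The step that bears most closely on this change is a 1.2-fold lower number from compound 2 to compound 3 (0.06 log units; within the scatter), in which one group on the same aromatic carbon was exchanged for another and the number stayed within the scatter. The step of an at least 5.0-fold higher number from compound 1 to compound 3 (0.69 log units; beyond the scatter) concerns a different exchange, of the whole group on the saturated chain carbon, and speaks less to this change. Compound 4 is therefore expected to show no step beyond the scatter, a 1.4-fold lower number from compound 3 to compound 4 (0.14 log units; within the scatter). The estimate for compound 4 is 1.8 mL.min-1.g-1, with a range from 0.7 mL.min-1.g-1 to 4 mL.min-1.g-1.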

Compound 4, intrinsic clearance in microsomes: 0.5 mL.min-1.g-1
Compound 4: middle estimate off by 3.6-fold (0.56 log units), on the high side; measured number outside the range, below it.
By their numbers in this assay, from the lowest: compound 4; then compounds 3 and 2 (each within the scatter of the next).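

Up to this point, the aromatic carbon para to a large group had shown no movement in this assay: the exchange of trifluoromethoxy for cyano stayed within the scatter, as a 1.2-fold lower number from compound 2 to compound 3 (0.06 log units; within the scatter) shows. Compound 4 shows that a group on this same carbon can shift the number beyond the scatter, with a 5.0-fold lower number from compound 3 to compound 4 (0.70 log units; beyond the scatter) and a 5.8-fold lower number from compound 2 to compound 4 (0.76 log units; beyond the scatter), so the sulfur-bearing group stands apart from both groups it is compared with, while those two cannot be told apart in this measurement. Compound 1 is reported only as a limit: the limit of < 0.5 mL.min-1.g-1 in this assay, at which 1 of the 4 values shown sits. The size of the step of a number no lower from compound 1 to compound 4 (the limit leaves the size open) cannot be read.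

What the compounds shown leave open is whether other groups on this aromatic carbon would give a step like a 5.0-fold lower number from compound 3 to compound 4 (0.70 log units; beyond the scatter) or one like a 1.2-fold lower number from compound 2 to compound 3 (0.06 log units; within the scatter) within the scatter. They also do not tell why the sulfur-bearing group gives the lower number, or whether it would do so at another place on the ring.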